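The source may hold more compounds than are shown below. What is called first, only, known or untested is meant among the compounds shown, and "the series" means these compounds.

Compound 1 `CCCNc1nc(-c2ccccc2)nc2c1nnn2Cc1ccccc1`: in an assay on Cerebral cortex for displacement of a labelled ligand from adenosine receptor A1 (Bos taurus) (a higher number here means a weaker inhibitor, a lower number a stronger inhibitor), compound 1 gives 37 nM
Compound 2 `c1ccc(Cn2nnc3c(NC4CCCC4)nc(-c4ccccc4)nc32)cc1`: in this assay compound 2 gives 11 nM

Among the measured compounds shown here, compound 2 has the lower of the two numbers in this assay, and the only measured step is a 3.4-fold lower number from compound 1 to compound 2 (0.53 log units; beyond the scatter). Compound 3 `OCCCNc1nc(-c2ccccc2)nc2c1nnn2Cc1ccccc1` has not yet been measured; it differs from compound 2 by 3-hydroxypropyl in place of cyclopentyl on a nitrogen on an aromatic ring. That measured step bears directly on this change, since it shows that a cyclopentyl in place of a propyl chain lowered the number. Going back from the cyclopentyl to a chain, now carrying a hydroxyl, the change to compound 3 is therefore expected to read a 5.5-fold higher number from compound 2 to compound 3 (0.74 log units; beyond the scatter). Compound 3 is expected to give about 60 nM, with a range from 20 nM to 200 nM.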

Compound 3, inhibition constant: 21.4 nM
Beside the measured number, compound 3's estimate is 2.8-fold (0.45 log units) above it; the measured number falls inside the stated range.
By their numbers in this assay, from the lowest: compounds 2, 3 and 1 (each within the scatter of the next, the first and the last beyond it).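

Adding a hydroxy group to the propyl chain gives a 1.7-fold lower number from compound 1 to compound 3 (0.24 log units; within the scatter) in this assay, and replacing cyclopentyl with 3-hydroxypropyl gives a 1.9-fold higher number from compound 2 to compound 3 (0.29 log units; within the scatter). Both steps lie within the scatter, so on this nitrogen the open chain carrying a hydroxy group cannot be told apart from either earlier group, even though those two differ beyond the scatter. Nothing measured here offers an explanation for this result.

Going by these compounds, whether a longer chain carrying the hydroxy group, or an amine in place of the hydroxy group, would give a similar number remains open.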